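Swapping the aryl ring on compound 1 before it is measured

A few compounds are considered here, and "the series" means these few. Any claim that something is new, unique, unknown or untested is made for them only; others in the source may bear on it.

The measured compounds so far:
- compound 1 `COc1ccccc1/C=C/C(=O)c1ccc(OCC(=O)N[C@H]2CCOC2=O)cc1` gives 39400 nM in a functional assay on MGC-803 cells (Homo sapiens) for antiproliferative activity, read by MTT assay, with a stated time of 72 h; on this read-out higher numbers stand for weaker inhibition and lower numbers for stronger inhibition
- compound 2 `CC(C)c1ccc(NCC(=O)N[C@H]2CCOC2=O)cc1` gives > 64000 nM in this assay, a limit rather than a number
- compound 3 `C=CCc1ccc(OCCSC(=S)N[C@H]2CCOC2=O)c(OC)c1` gives 27900 nM in this assay

Among the compounds with values here, only two compounds return a number. Compound 1 stands at the upper end of those two, but its gap to compound 3 is within the usual scatter, so the two cannot be told apart on this evidence. For compound 2 the assay reports only a limit (the limit of > 64000 nM in this assay, at which 1 of the 3 values shown sits).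

The next compound, compound 4 `O=C(COc1ccc(C(=O)/C=C/c2ccc(F)c(F)c2)cc1)N[C@H]1CCOC1=O`, keeps the whole core of compound 1 and changes one ring: 3,4-difluorophenyl in place of 2-methoxyphenyl on a double-bonded chain carbon bound to a double-bonded chain carbon. Within the data shown here, no pair of measured compounds shows this kind of swap, so its effect has to be guessed. With nothing to point to, the expectation is a step from compound 1 to compound 4 of modest size, most likely toward stronger inhibition but not clearly beyond the scatter: a 1.6-fold lower number from compound 1 to compound 4 (0.20 log units; within the scatter). Compound 4 is therefore estimated at 25000 nM in this assay, with a plausible range from 8000 nM to 70000 nM.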

Compound 4, half-maximal inhibitory concentration: > 64000 nM
Compound 4: a limit, no number; the forecaster's own chance of this, stated with the estimate: 15%; middle value at least 2.5-fold (0.40 log units) from the limit.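

In this assay, 3,4-difluorophenyl in place of 2-methoxyphenyl on a double-bonded chain carbon bound to a double-bonded chain carbon gives the only single-place comparison shown so far: an at least 1.6-fold higher number from compound 1 to compound 4 (0.21 log units; that floor lies within the scatter). Compound 4 gives > 64000 nM, which is a limit and not a number, so this step has a floor but no upper end, and that floor alone does not separate the two compounds. The swap therefore gives no sign of stronger inhibition at this position, and the limit is a frequent outcome in this small set, so the true size of the change stays hidden: the limit of > 64000 nM in this assay, at which 2 of the 4 values shown sit.

Within the data shown here, with only one swap at this position, the effect of losing the methoxy group cannot be separated from the effect of adding the two fluorines. A plain phenyl ring would help to separate them, while a phenyl ring carrying an amine or a carboxylic acid would show whether this position accepts quite different groups on the same core.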